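The compounds below may be only part of what the source reports. "The series", "measured", "known", "first", "only" and "open" are said of these compounds alone.

Compound 1 `COc1ccc(S(N)(=O)=O)cc1C(=O)Nc1cccc(-c2nncn2C(C)C)n1` is the reference of this pair. Among the compounds with values here, in an assay for inhibition of serine/threonine-protein kinase TAO2 (Homo sapiens), tested at 1 uM (on this read-out higher numbers stand for more inhibition at the one concentration tested (going by the name of the read-out) and lower numbers for less inhibition), compound 1 gives -1%; its one measured neighbour, compound 2 `COc1cc(C)c(S(N)(=O)=O)cc1C(=O)Nc1cccc(-c2nncn2C(C)C)n1`, gives -3% in this assay, and the two values lie within the scatter of each other, the step of a number 2 percentage points lower from compound 1 to compound 2 (within the scatter) being small. Compound 3 `COc1ccc(S(C)(=O)=O)cc1C(=O)Nc1cccc(-c2nncn2C(C)C)n1` carries the change (methyl in place of amino on a sulfonyl sulfur). Within the data shown here, no measured step touches the sulfonyl sulfur, and the only step known is the unchanged methyl step to compound 2, so no shift beyond the scatter is expected, a number 1 percentage points lower from compound 1 to compound 3 (within the scatter). Compound 3 is therefore estimated at -2%, expected to fall between -12% and 8%.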

Compound 3, a percentage reported as inhibition, at one concentration (the size of the read-out at that concentration, not a potency): 0%
The estimate for compound 3 lay 2 percentage points below the measured number; measured number inside the range.
By their numbers in this assay, from the lowest: compounds 2, 1 and 3 (each within the scatter of the next).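

In this assay, methyl in place of amino on a sulfonyl sulfur gives a number 1 percentage points higher from compound 1 to compound 3 (within the scatter), the first step read at this position. The hydrogen-bond donor of the amino group can thus be lost in the sulfamoyl to methylsulfonyl change with no shift beyond the scatter. Nothing at hand offers an explanation for this result. As far as these compounds go, whether a dimethylamino group or a longer chain such as propyl on the sulfonyl sulfur would read differently remains open.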